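Swapping tert-butyl for 4-bromophenyl on compound 1

This account rests on a few compounds, and the source may have more. Where it says the series, first, only, none or still open, it means among the compounds named here.

Compound 1 `CC(C)(C)c1cn(C[C@H](O)[C@H]2OC(=O)C(OCc3ccccc3)=C2OCc2ccccc2)nn1` is assessed in a functional assay on CFPAC-1 cells (Homo sapiens) for antiproliferative activity, read by MTT assay, with a stated time of 72 h (a higher number here means a weaker inhibitor, a lower number a stronger inhibitor), where compound 1 gives 54900 nM. Among the two numbers shown, compound 1 carries the highest, with compound 3 `O=C1O[C@H]([C@@H](O)Cn2cc(CNS(=O)(=O)c3ccc(Cl)cc3)nn2)C(OCc2ccccc2)=C1OCc1ccccc1` nearest: in this assay compound 3 gives 38900 nM, and the step of a 1.4-fold lower number from compound 1 to compound 3 (0.15 log units; within the scatter) lies within the scatter. Compound 2 `O=C1O/C(=C\Cn2cc(-c3ccc(Br)cc3)nn2)C(OCc2ccccc2)=C1OCc1ccccc1`, built on a different core, reaches only a limit of the assay, > 100000 nM; it is a limit and not a number (the limit of > 100000 nM in this assay, at which 1 of the 3 values shown sits).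

Compound 4 `O=C1O[C@H]([C@@H](O)Cn2cc(-c3ccc(Br)cc3)nn2)C(OCc2ccccc2)=C1OCc1ccccc1` keeps the core of compound 1 and changes one group: 4-bromophenyl in place of tert-butyl on an aromatic carbon. No measured step follows this exchange of tert-butyl for 4-bromophenyl, so nothing shown sizes it directly. Among the compounds with values here, the only measured step on this core, from compound 1 to compound 3, stayed within the scatter, and compound 2, bearing the same 4-bromophenyl group on another core, gave only a limit. Compound 4 is therefore expected to remain a weak inhibitor, with a step of a 1.1-fold higher number from compound 1 to compound 4 (0.04 log units; within the scatter) that is estimated to stay near the scatter. The expected value for compound 4 in this assay is 60000 nM, in a range from 25000 nM to 150000 nM.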

Compound 4, half-maximal inhibitory concentration: 5830 nM
Compound 4: middle estimate off by 10-fold (1.01 log units), on the high side, and the stated range ends above it.
By their numbers in this assay, from the lowest: compound 4; then compounds 3 and 1 (each within the scatter of the next). At a limit, above all of these: compound 2.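

Within the data shown here, the group on this aromatic carbon of the five-membered ring can move the number after all: this assay records a 9.4-fold lower number from compound 1 to compound 4 (0.97 log units; beyond the scatter), whereas the only earlier exchange at this place gave a 1.4-fold lower number from compound 1 to compound 3 (0.15 log units; within the scatter). The 4-bromophenyl group also separates from the (((4-chlorophenyl)sulfonyl)amino)methyl group, with a 6.7-fold lower number from compound 3 to compound 4 (0.82 log units; beyond the scatter), so among the groups shown on this core it alone stands apart from the others. The same group does not give a number on every core, as compound 2, which carries 4-bromophenyl on a different core, stands at a limit and not a number: the limit of > 100000 nM in this assay, at which 1 of the 4 values shown sits.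

The compounds shown leave open whether the bromine or the six-membered aromatic ring itself goes with the lower number. A plain phenyl or a 4-chlorophenyl group at this carbon would separate the two.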